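The source may report more compounds than this note shows. Statements on the series, on what has been measured and on what is new or still open speak of the compounds shown alone.

Measured compounds:
compound 1, `C=CCn1c(SCC(=O)c2ccccc2)nnc1-c1ccccc1`, giving 70%
compound 2, `C=CCn1c(SC/C(=N\O)c2ccccc2)nnc1-c1ccc(OC)c(OC)c1`, giving 58%
compound 3, `COc1ccc(-c2nnc(SC/C(=N/O)c3ccccc3)n2-c2ccccc2)cc1`, giving 63%

These three compounds share one core and were all tested in a functional assay on the whole organism (strain albino) for inhibition, with Rattus norvegicus as the target, read by paw edema, with a stated time of 3 h, at a dose of 0.28 mmol/kg by the oral route; a lower number here means less inhibition, a higher number more inhibition at the dose given (going by the name of the read-out). In this assay compound 1 gives 70%. Compound 3 gives 63%, a number that lies within the usual scatter of the value of compound 1, so the two cannot be told apart. Compound 2 gives 58%, which lies beyond the scatter below the value of compound 1, so compound 1 stands above compound 2 and level with compound 3.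

Compound 4, `C=CCn1c(SCC(=O)c2ccccc2)nnc1-c1ccc(OC)cc1`, has not yet been measured. It differs from compound 1 in one place: methoxy in place of hydrogen on an aromatic carbon. Among the compounds with values here, no pair of measured compounds differs in exactly this way, so the size of the step rests on the wider picture, in which compound 3, carrying a methoxy group and giving 63%, sits close to compound 1. The step of a number 6 percentage points lower from compound 1 to compound 4 (within the scatter) is therefore expected to be small, within the scatter, with no clear direction. Compound 4 is expected to give about 64%, in a range from 50% to 76%.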

Compound 4, a percentage reported as inhibition, in the whole organism at one dose (the size of the read-out at that dose, not a potency): 63%
Beside the measured number, compound 4's estimate is 1 percentage points above it; the measured number falls inside the stated range.
By their numbers in this assay, from the lowest: compounds 2, 3, 4 and 1 (each within the scatter of the next, the first and the last beyond it).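

Within the data shown here, the new result gives the first pair in the set that differs in one place only, so the change from phenyl to 4-methoxyphenyl can now be read directly in this assay: it amounts to a number 7 percentage points lower from compound 1 to compound 4 (within the scatter). On this aromatic carbon, para to a large group, methoxy in place of hydrogen therefore leaves the inhibition at this dose level, with no direction that can be told from the scatter. Nothing at hand bears on what lies behind this reading.

The compounds shown leave open whether other groups at this place, such as a chlorine atom, a hydroxyl or an amine, would read the same. They also leave open whether the same change would read alike on a compound carrying the oxime in place of the carbonyl.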